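Benzyl Carbamate in Place of Ethyl on the Fluorophenyl Core

A few compounds are considered here, and "the series" means these few. Any claim that something is new, unique, unknown or untested is made for them only; others in the source may bear on it.

Going by the values given here, compound 2 `CCOC(=O)N1CCC(c2cc(O)n3nc(C)c(-c4ccc(F)cc4)c3n2)CC1` gives 497 nM in an assay on HEK293 cells for agonist activity at short transient receptor potential channel 7 (Homo sapiens), read by fluorescence and calcium flux, with a stated time of 2.5 min, in the presence of a further agent that is not named here (a lower number here means that less compound is needed, a higher number that more compound is needed for the effect), the highest of the two numbers known here; its nearest neighbour, compound 1 `Cc1nn2c(O)cc(C3CCN(C(=O)OCc4ccccc4)CC3)nc2c1-c1ccc(Cl)cc1`, gives 213 nM, a gap beyond the scatter. Compound 3 `Cc1nn2c(O)cc(C3CCN(C(=O)OCc4ccccc4)CC3)nc2c1-c1ccc(F)cc1` keeps the core of compound 2 and differs only by phenyl in place of methyl on a saturated chain carbon bound to an oxygen next to a carbonyl group. Among the compounds with values here, no measured pair shows that change alone, so its size is open. Because compound 1 carries the benzyloxycarbonyl and gives 213 nM, a modest lowering is expected. The step of a 1.7-fold lower number from compound 2 to compound 3 (0.22 log units; within the scatter) is therefore expected to lie about at the edge of the scatter. Compound 3 is estimated at 300 nM, within 120 nM to 750 nM.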

Compound 3, half-maximal effective concentration: 314 nM
Compound 3: middle estimate off by 1.0-fold (0.02 log units), on the low side; the range from low to high includes it.
By their numbers in this assay, from the lowest: compounds 1, 3 and 2 (each within the scatter of the next, the first and the last beyond it).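

In this assay, phenyl in place of methyl on a saturated chain carbon bound to an oxygen next to a carbonyl group gives a 1.6-fold lower number from compound 2 to compound 3 (0.20 log units; within the scatter), so this change, now read alone, stays within the scatter. Fluoro in place of chloro on an aromatic carbon gives a 1.5-fold higher number from compound 1 to compound 3 (0.17 log units; within the scatter), so neither place shows a step beyond the scatter. No measurement here gives a reason for either step.

As far as these compounds go, whether cyclohexyl in place of phenyl, or bromo in place of fluoro, would give a step beyond the scatter stays open.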